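From Ethoxy to 4-Aminophenoxy on the Shared Core

The source may report more compounds than this note shows. Statements on the series, on what has been measured and on what is new or still open speak of the compounds shown alone.

Going by the values given here, in a functional assay on HeLa cells (Homo sapiens) for antiproliferative activity, read by cell counting, with a stated time of 3 days (a lower number here means a stronger inhibitor, a higher number a weaker inhibitor), compound 3 `CCOc1ccccc1NC(C)=C1C(=O)CC(c2ccccc2)CC1=O` gives 180 nM and stands highest of the three numbers so far. Compound 2 `CC(Nc1ccccc1Oc1ccc(C(C)O)cc1)=C1C(=O)CC(c2ccccc2)CC1=O` gives 75 nM in this assay and compound 1 `COc1ccc(Oc2ccccc2NC(C)=C2C(=O)CC(c3ccccc3)CC2=O)cc1OC` gives 54 nM in the same test. Compound 4 `CC(Nc1ccccc1Oc1ccc(N)cc1)=C1C(=O)CC(c2ccccc2)CC1=O` has 4-aminophenyl in place of ethyl on an oxygen on an aromatic ring and differs as follows: 4-aminophenyl in place of ethyl on an oxygen on an aromatic ring is the full count of that change. Among the compounds with values here, two measured steps bear on it, since each puts ethyl on that oxygen in place of a substituted phenyl. The first is a 3.3-fold higher number from compound 1 to compound 3 (0.52 log units; beyond the scatter) and the second is a 2.4-fold higher number from compound 2 to compound 3 (0.38 log units; beyond the scatter) and both are modest. The two phenyl groups themselves show a 1.4-fold higher number from compound 1 to compound 2 (0.14 log units; within the scatter) as their step. Read in reverse, these steps point to a modest fall in the number, although no 4-aminophenyl compound has yet been measured. The expected change is a 2.6-fold lower number from compound 3 to compound 4 (0.41 log units; beyond the scatter) in this assay by this estimate. For compound 4 the estimate is 70 nM with 25 nM to 180 nM as the expected range.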

Compound 4, half-maximal inhibitory concentration: 39 nM
The estimate for compound 4 lay 1.8-fold (0.25 log units) above the measured number; low and high end bracket the measured number.
By their numbers in this assay, from the lowest: compounds 4, 1 and 2 (each within the scatter of the next); then compound 3.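

In this assay, a third substituted phenyl group on the oxygen also separates from ethyl beyond the scatter, at a 4.6-fold lower number from compound 3 to compound 4 (0.66 log units; beyond the scatter), so compounds 1, 2 and 4 all give lower numbers than compound 3 and none of the four goes against this. The substituents on that phenyl group do not separate in the same way: amino in place of 1-hydroxyethyl gives a 1.9-fold lower number from compound 2 to compound 4 (0.28 log units; within the scatter), and 4-aminophenyl in place of 3,4-dimethoxyphenyl gives a 1.4-fold lower number from compound 1 to compound 4 (0.14 log units; within the scatter). At this position, the clear difference so far lies between ethyl and the substituted phenyl groups, not among those groups. Nothing shown here accounts for this difference. Going by these compounds, it remains open whether plain phenyl, a phenyl group carrying a carboxylic acid, or a longer chain such as butyl on that oxygen would follow the substituted phenyl groups or ethyl.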